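Methyl added to the fused ring of compound 3

The source may report more compounds than this note shows. Statements on the series, on what has been measured and on what is new or still open speak of the compounds shown alone.

Compound 1 `Cc1ccc(-c2ccc(C(=O)O)cc2)cc1-c1ccc2c(c1)C(C)(C)CCC2(C)C` and compound 2 `Cc1ccc(-c2ccc(C(=O)O)cc2)cc1-c1cc2c(cc1C)C(C)(C)CCC2(C)C` share the core with the two unmeasured-free pair below. In an assay on CV-1 cells (Cercopithecidae) for activation of retinoic acid receptor gamma (Homo sapiens) (on this read-out lower numbers stand for an effect already at smaller amounts and higher numbers for an effect only at larger amounts of compound), compound 1 reports only a limit, < 1 nM (the limit of < 1 nM in this assay, at which 1 of the 3 values shown sits). Compound 2 gives 1 nM in this assay. The step of a number no lower from compound 1 to compound 2 (the limit leaves the size open) is therefore open in size, since one end rests on a limit (the limit of < 1 nM in this assay, at which 1 of the 3 values shown sits). Compound 3 `CC1(C)CCC(C)(C)c2cc(-c3cccc(-c4ccc(C(=O)O)cc4)n3)ccc21` reports only a limit in this assay, > 1000 nM (the limit of > 1000 nM in this assay, at which 1 of the 3 values shown sits). Compound 4 `Cc1cc2c(cc1-c1cccc(-c3ccc(C(=O)O)cc3)n1)C(C)(C)CCC2(C)C` differs from compound 3 by methyl in place of hydrogen on an aromatic carbon, ortho to a large group, meta to a fused ring, para to a fused ring. Among the compounds with values here, the only measured step bearing on this change is a number no lower from compound 1 to compound 2 (the limit leaves the size open), whose size is not readable. The step that the limit leaves unreadable from compound 3 to compound 4 is expected to fall within the scatter. Compound 4 is estimated at 2000 nM, between 500 nM and 10000 nM.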

Compound 4, concentration for half-maximal activity: 1000 nM
The estimate for compound 4 lay 2.0-fold (0.30 log units) above the measured number; low and high end bracket the measured number.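

On the core of compound 3, methyl in place of hydrogen on this aromatic carbon now has a number: in this assay compound 4 gives 1000 nM. Compound 3 carries only a limit, > 1000 nM. The result is a number no higher from compound 3 to compound 4 (the limit leaves the size open). The steps on both cores cannot be read, so the same change now stands on two cores with neither size known: the same change on two cores in this assay, a number no lower (the limit leaves the size open) from compound 1 to compound 2 and a number no higher (the limit leaves the size open) from compound 3 to compound 4; the limit leaves it open whether they differ

Open, on these data alone, is how far compound 3 actually lies from compound 4. Also open, as far as these compounds go, is whether ethyl or methoxy on this same aromatic carbon would give a readable step on either core.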